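A shorter chain on compound 2

This account rests on a few compounds, and the source may have more. Where it says the series, first, only, none or still open, it means among the compounds named here.

- compound 1 `C/C=C1/[C@H](O[C@@H]2O[C@H](CO)[C@@H](O)[C@H](O)[C@H]2O)OC=C(C(=O)OC)[C@H]1CC(=O)OCCCCCCCCCCCCCCC` gives 1500 nM
- compound 2 `C/C=C1/[C@H](O[C@@H]2O[C@H](COC(C)=O)[C@@H](OC(C)=O)[C@H](OC(C)=O)[C@H]2OC(C)=O)OC=C(C(=O)OC)[C@H]1CC(=O)OCCCCCCCCCCCCCCC` gives 34100 nM

In a functional assay on B16-F1 cells (Mus musculus) for antiproliferative activity, read by MTT assay, with a stated time of 72 h (a lower number here means a stronger inhibitor, a higher number a weaker inhibitor), compound 2 stands highest of the two measured compounds at 34100 nM and is the weaker inhibitor, beyond the scatter of compound 1. Compound 3 `C/C=C1/[C@H](O[C@@H]2O[C@H](COC(C)=O)[C@@H](OC(C)=O)[C@H](OC(C)=O)[C@H]2OC(C)=O)OC=C(C(=O)OC)[C@H]1CC(=O)OCCC` differs from compound 2 by one change (hydrogen in place of dodecyl on a saturated chain carbon, three bonds along the chain from an oxygen next to a carbonyl group): hydrogen in place of dodecyl on a saturated chain carbon, three bonds along the chain from an oxygen next to a carbonyl group. Within the data shown here, no measured pair shows this change alone. A modest rise toward weaker inhibition is expected, with the estimated step of a 1.8-fold higher number from compound 2 to compound 3 (0.25 log units; within the scatter) as its size. The estimated value for compound 3 is 60000 nM (range 20000 nM to 200000 nM).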

Compound 3, half-maximal inhibitory concentration: 44000 nM
Beside the measured number, compound 3's estimate is 1.4-fold (0.13 log units) above it; the measured number falls inside the stated range.
By their numbers in this assay, from the lowest: compound 1; then compounds 2 and 3 (each within the scatter of the next).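

In this assay, hydrogen in place of dodecyl on a saturated chain carbon, three bonds along the chain from an oxygen next to a carbonyl group, gives a 1.3-fold higher number from compound 2 to compound 3 (0.11 log units; within the scatter). Among these compounds, this is the first step read at this position, and it shows that the full length of the chain does not separate compound 2 from compound 3 in this assay. No measurement shown here offers an explanation for this result. Going by these compounds, whether the same change would read alike on compound 1 stays open, as does how an amine or a carboxylic acid at this place would read.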